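Extending the Ring on a Carbamate Nitrogen

A few compounds are considered here, and "the series" means these few. Any claim that something is new, unique, unknown or untested is made for them only; others in the source may bear on it.

Three carbamates sharing one core have been measured in an assay on cell membranes (strain Wistar) for inhibition of Fatty-acid amide hydrolase 1 (Rattus norvegicus), read by scintillation counting; on this read-out lower numbers stand for stronger inhibition and higher numbers for weaker inhibition. Compound 1 `CCCCCCCCCCCCNC(=O)Oc1ccc(C2=NCCS2)cc1` gives 6.3 nM, compound 2 `CC(C)(C)NC(=O)Oc1ccc(C2=NCCS2)cc1` gives 7000 nM, and compound 3 `O=C(NC1CCCC1)Oc1ccc(C2=NCCS2)cc1` gives 130 nM, so compound 3 stands second highest of the three, well apart from compound 1 and well apart from compound 2. Compound 4 `O=C(NC1CCCCC1)Oc1ccc(C2=NCCS2)cc1` differs from compound 3 by cyclohexyl in place of cyclopentyl on an amide-type nitrogen. Among the compounds with values here, only one measured step bears on this change: a 54-fold lower number from compound 2 to compound 3 (1.73 log units; beyond the scatter), which shows that altering the group on the amide-type nitrogen can move the number a great deal. Because a 54-fold lower number from compound 2 to compound 3 (1.73 log units; beyond the scatter) moved the number down, a more modest drop is expected here, a 2.6-fold lower number from compound 3 to compound 4 (0.41 log units; beyond the scatter). Compound 4 is therefore estimated at 50 nM, with a range from 15 nM to 200 nM.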

Compound 4, half-maximal inhibitory concentration: 100 nM
Compound 4: the middle estimate sits 2.0-fold (0.30 log units) below what was measured; the measured number falls inside the stated range.
By their numbers in this assay, from the lowest: compound 1; then compounds 4 and 3 (each within the scatter of the next); then compound 2.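

In this assay, cyclohexyl in place of cyclopentyl on the amide-type nitrogen gives only a small step (a 1.3-fold lower number from compound 3 to compound 4 (0.11 log units; within the scatter)), which lies within the scatter, so these two rings read alike at this position. The large step seen from tert-butyl to cyclopentyl is matched with cyclohexyl (a 70-fold lower number from compound 2 to compound 4 (1.85 log units; beyond the scatter)). Nothing available here explains either step.

Going by these compounds, whether a cycloheptyl or phenyl ring on this nitrogen would read like these two rings remains open. So does how an open hexyl chain would compare with them.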